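Second methoxy on the benzyl ring of compound 2

This account rests on a few compounds, and the source may have more. Where it says the series, first, only, none or still open, it means among the compounds named here.

Compound 1 `O=C(NCc1cn(Cc2ccc(F)cc2)nn1)c1cn(-c2ccccc2)nc1-c1ccc(F)cc1` and compound 2 `COc1ccc(Cn2cc(CNC(=O)c3cn(-c4ccccc4)nc3-c3ccc(F)cc3)nn2)cc1` share one core and differ only on the benzyl ring. In a functional assay on HeLa cells (Homo sapiens) for antiproliferative activity, read by sulforhodamine B assay, with a stated time of 48 h (a higher number here means a weaker inhibitor of growth, a lower number a stronger inhibitor of growth), compound 1 gives 1200 nM. In this assay compound 2 gives 870 nM, and the pair sits within the scatter, as a 1.4-fold lower number from compound 1 to compound 2 (0.14 log units; within the scatter) shows. Compound 3 `COc1ccc(Cn2cc(CNC(=O)c3cn(-c4ccccc4)nc3-c3ccc(F)cc3)nn2)cc1OC` carries methoxy in place of hydrogen on an aromatic carbon, ortho to a methoxy group and meta to a large group. Within the data shown here, the only step that bears on this, the earlier change on the same ring, left the number unmoved, so the expected step of a 1.0-fold lower number from compound 2 to compound 3 (0.01 log units; within the scatter) stays within the scatter. Compound 3 is therefore estimated at 850 nM, with a range from 350 nM to 2000 nM.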

Compound 3, concentration for 50% growth inhibition: 200 nM
Beside the measured number, compound 3's estimate is 4.3-fold (0.63 log units) above it, outside the stated range (below it).
By their numbers in this assay, from the lowest: compound 3; then compounds 2 and 1 (each within the scatter of the next).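

Among these compounds, on the benzyl ring, a methoxy group placed ortho to the existing methoxy group gives the first single change beyond the scatter in this assay (a 4.4-fold lower number from compound 2 to compound 3 (0.64 log units; beyond the scatter)), whereas the earlier change on this ring was within it. Replacing 4-fluorophenyl with 3,4-dimethoxyphenyl also gives a step beyond the scatter (a 6.0-fold lower number from compound 1 to compound 3 (0.78 log units; beyond the scatter)). No measurement given here explains the stronger growth inhibition. The compounds shown leave open whether this step depends on the methoxy group already on the ring, and whether an ethoxy or a hydroxyl group in the same place would give a step of similar size.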